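Cyclopentyl for Cyclopropylmethyl on Two Related Cores

The source may hold more compounds than are shown below. What is called first, only, known or untested is meant among the compounds shown, and "the series" means these compounds.

Compound 2 `COc1ccccc1OCCNc1ccc(=O)n(Cc2ccc(OC)c(OCC3CC3)c2)n1` was tested in a functional assay on SH-SY5Y cells (Homo sapiens) for antiproliferative activity, read by MTT assay, with a stated time of 48 h (on this read-out lower numbers stand for stronger inhibition of growth and higher numbers for weaker inhibition of growth), where compound 2 gives 10500 nM. Compound 1 `COc1ccccc1OCCNc1ccc(=O)n(Cc2ccc(OC)c(OC3CCCC3)c2)n1` differs from it by cyclopentyl in place of cyclopropylmethyl on an oxygen on an aromatic ring. In this assay compound 1 reaches only the limit > 100000 nM. The resulting step is an at least 9.5-fold higher number from compound 2 to compound 1 (0.97 log units; beyond the scatter).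

Compound 3 `COc1ccccc1OCCNc1cnn(Cc2ccc(OC(F)F)c(OCC3CC3)c2)c(=O)c1Cl` carries a different core; how the two cores differ is not broken down here. In this assay compound 3 gives only the limit > 100000 nM. Compound 4 `COc1ccccc1OCCNc1cnn(Cc2ccc(OC(F)F)c(OC3CCCC3)c2)c(=O)c1Cl` differs from compound 3 by cyclopentyl in place of cyclopropylmethyl on an oxygen on an aromatic ring, the same change made from compound 2 to compound 1.

Compound 4 is expected to give about 150000 nM, between 50000 nM and 500000 nM. The expected step is a step that the limit leaves unreadable from compound 3 to compound 4, near zero only because compound 3 already sits at the limit of > 100000 nM in this assay, at which 2 of the 3 values shown sit. This expectation also rests on the direction of an at least 9.5-fold higher number from compound 2 to compound 1 (0.97 log units; beyond the scatter), so a reported limit rather than a number is likely for compound 4.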

Compound 4, concentration for 50% growth inhibition: > 100000 nM
Compound 4: a limit, no number (the forecaster's own chance of this, stated with the estimate: 85%); the middle value lies beyond the limit too.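

Compound 3 and compound 4 both stand only at a limit in this assay, so no step between them can be read: the limit of > 100000 nM in this assay, at which 3 of the 4 values shown sit.

From the compounds shown here alone, whether cyclopentyl in place of cyclopropylmethyl raises the number on the core of compound 3, as it does on the core of compound 1, stays open.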